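Acetyl to Methoxy on the Pendant Phenyl Ring

This account rests on a few compounds, and the source may have more. Where it says the series, first, only, none or still open, it means among the compounds named here.

Measured compounds:
Compound 1 `Nc1scc(-c2cccc(C(F)(F)F)c2)c1C(=O)c1ccccc1`: 15.8 uM
Compound 2 `CC(=O)c1ccc(-c2sc(N)c(C(=O)c3ccccc3)c2-c2cccc(C(F)(F)F)c2)cc1`: > 10 uM

In a functional assay on CHO-K1 cells for agonist activity at adenosine receptor A1 (Homo sapiens), read by GTPgammaS binding (on this read-out higher numbers stand for an effect only at larger amounts of compound and lower numbers for an effect already at smaller amounts), compound 1 gives 15.8 uM. For compound 2 the read-out is a limit of the assay, > 10 uM, and not a number. Going by the values given here, compound 2 thus stands at the limit of > 10 uM in this assay, at which 1 of the 2 values shown sits, and the only recorded step, a step that the limit leaves unreadable from compound 1 to compound 2, carries no readable size.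

Compound 3 `COc1ccc(-c2sc(N)c(C(=O)c3ccccc3)c2-c2cccc(C(F)(F)F)c2)cc1` differs from compound 2 by methoxy in place of acetyl on an aromatic carbon. Among the compounds with values here, no measured step touches this exchange, and the one step that exists, from compound 1 to compound 2, is itself unreadable in this assay, so there is nothing to say about direction or size of the change beyond the scatter.

Since compound 2 sits at the limit of > 10 uM in this assay, at which 1 of the 2 values shown sits, compound 3 is expected to stay in the weak region as well, which means an expected step that the limit leaves unreadable from compound 2 to compound 3. Compound 3 is therefore estimated at 20 uM in this assay, with a range from 5 uM to 80 uM, and a real chance that the assay again reports only a limit.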

Compound 3, concentration for half-maximal effect: > 10 uM
Compound 3: a limit, no number; the forecaster's own chance of this, stated with the estimate: 60%; the middle value lies beyond the limit too.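

In this assay compound 3 gives > 10 uM, which is a limit of the assay and not a number. Going by these compounds alone, compound 2 also stands at a limit, so no step among compound 1, compound 2 and compound 3 can be read: the limit of > 10 uM in this assay, at which 2 of the 3 values shown sit. Going by these compounds, whether 4-acetylphenyl and 4-methoxyphenyl differ from each other, or from the hydrogen of compound 1, stays open.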